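Cytotoxicity in Vero Cells after Adding a Phenyl

The compounds below may be only part of what the source reports. "The series", "measured", "known", "first", "only" and "open" are said of these compounds alone.

Compound 1 `CN1CCc2cc(OCc3ccccc3)ccc2C1`: in an ADME assay on Vero cells (Chlorocebus sabaeus) for cytotoxicity, read by sulforhodamine B assay, with a stated time of 72 h (a higher number here means a weaker inhibitor, a lower number a stronger inhibitor), compound 1 reaches only the limit > 100000 nM.
Compound 2 `CN1CCc2cc(OCc3ccc(-c4ccccc4)cc3)ccc2C1`: in this assay compound 2 gives 16500 nM.
Compound 3 `CN1CCc2cc(-c3ccccc3)ccc2C1`: in this assay compound 3 reaches only the limit > 50000 nM.

Compound 2 differs from compound 1 by phenyl in place of hydrogen on an aromatic carbon, and that change brought an at least 6.0-fold lower number from compound 1 to compound 2 (0.78 log units; beyond the scatter). The difference between the core of compound 1 and the core of compound 3 is not broken down here. Compound 4 `CN1CCc2cc(-c3ccc(-c4ccccc4)cc3)ccc2C1` differs from compound 3 by phenyl in place of hydrogen on an aromatic carbon, the same change, so the step from compound 3 to compound 4 is expected to be an at least 3.3-fold lower number from compound 3 to compound 4 (0.52 log units; beyond the scatter), resting on an at least 6.0-fold lower number from compound 1 to compound 2 (0.78 log units; beyond the scatter), though compound 3 stands at a limit that leaves its true value open. For compound 4 in this assay the estimate is therefore 15000 nM, expected between 5000 nM and 60000 nM.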

Compound 4, half-maximal inhibitory concentration: 15600 nM
Beside the measured number, compound 4's estimate is 1.0-fold (0.02 log units) below it; low and high end bracket the measured number.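

In this assay, phenyl in place of hydrogen on an aromatic carbon brought an at least 3.2-fold lower number from compound 3 to compound 4 (0.50 log units; beyond the scatter), and the number fell in the same direction on both cores shown: the same change on two cores in this assay, an at least 6.0-fold lower number (0.78 log units; beyond the scatter) from compound 1 to compound 2 and an at least 3.2-fold lower number (0.50 log units; beyond the scatter) from compound 3 to compound 4; the limit leaves it open whether they differ

Both steps start from a limit of the assay rather than from a number, which leaves the true size of each step unknown. Two cores show that the direction held in these pairs, but they do not show that the change would carry the same size, or the same direction, to other cores in the series.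

Going by these compounds, whether an amine, a carboxylic acid or a longer chain in place of the added phenyl would also lower the number in this assay remains open. Also open, on these data alone, is how the phenyl would behave on any further core.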